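This account rests on a few compounds, and the source may have more. Where it says the series, first, only, none or still open, it means among the compounds named here.

Working notes on the series.

Compound 1 `COc1ccc2c(/C=C(\C#N)C(=O)c3c[nH]c4cc(F)ccc34)c[nH]c2c1` and compound 2 `COc1ccc2c(/C=C(\C#N)C(=O)c3c[nH]c4cc(OC)ccc34)c[nH]c2c1` share one core; compound 3 `COc1ccc2[nH]cc(/C=C(\C#N)C(=O)c3c[nH]c4cc(F)ccc34)c2c1` and compound 4 `COc1ccc2c(C(=O)/C(C#N)=C/c3c[nH]c4ccc(OC)cc34)c[nH]c2c1` share another, built from the same atoms joined differently. The difference between the two cores is not broken down here.

In a functional assay on A549 cells (Homo sapiens) for cytotoxicity, read by WST assay, with a stated time of 48 h (a higher number here means a weaker inhibitor, a lower number a stronger inhibitor), compound 1 gives 5500 nM, and compound 2 gives 1700 nM. The change that separates them is methoxy in place of fluoro on an aromatic carbon, and it produced a 3.2-fold lower number from compound 1 to compound 2 (0.51 log units; beyond the scatter). Going by the values given here, compound 3 gives 26300 nM in this assay, the highest number of the three measured so far and beyond the scatter against both compound 1 and compound 2; what its two values with compound 1 show is a gap that is not itself broken down into a single structural change.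

Among the compounds with values here, the change from compound 3 to compound 4 is methoxy in place of fluoro on an aromatic carbon, the same change as the one from compound 1 to compound 2, made on the other core. It occurs twice among the compounds shown. Within the data shown here, with only one measured instance of it, the expectation for compound 4 rests on that single precedent: the step from compound 3 to compound 4 is estimated as a 2.9-fold lower number from compound 3 to compound 4 (0.47 log units; beyond the scatter), of about the size seen in a 3.2-fold lower number from compound 1 to compound 2 (0.51 log units; beyond the scatter). On these data alone, whether the change transfers to the second core is untested, so the range is kept wide. The estimate for compound 4 in this assay is 9000 nM, expected to fall between 3500 nM and 23000 nM.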

Compound 4, half-maximal inhibitory concentration: 5500 nM
Beside the measured number, compound 4's estimate is 1.6-fold (0.21 log units) above it; low and high end bracket the measured number.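

In this assay, methoxy in place of fluoro on an aromatic carbon gives a 4.8-fold lower number from compound 3 to compound 4 (0.68 log units; beyond the scatter), so the number falls on the second core as it did on the first. Set beside the earlier step, this one does not differ from it beyond what repeated measurement would produce: the same change on two cores in this assay, a 3.2-fold lower number (0.51 log units; beyond the scatter) from compound 1 to compound 2 and a 4.8-fold lower number (0.68 log units; beyond the scatter) from compound 3 to compound 4, 1.5-fold (0.17 log units) apart, within the scatter of two such steps. The direction and approximate size of the change therefore carry over between these two cores, but this rests on two pairs of compounds, one pair of groups and one assay, so it sets no rule for any other core and does not show why the number falls.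

The compounds shown carry only fluoro or methoxy on this aromatic carbon, so it remains open whether a hydroxyl, an amine or a longer alkoxy chain there would follow the same course on either core. Going by these compounds alone, what the difference between the two cores contributes on its own also remains open, as no step between them reads as a single structural change.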